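Cytotoxic thiazolidinedione analogs: removing a methyl from the benzyl

A few compounds are considered here, and "the series" means these few. Any claim that something is new, unique, unknown or untested is made for them only; others in the source may bear on it.

Measured compounds in a functional assay on FM3A cells (Mus musculus) for cytotoxicity, read by cell counting, with a stated time of 2 days; on this read-out higher numbers stand for weaker inhibition and lower numbers for stronger inhibition:
Compound 1, `C=C(Br)C(=O)Nc1cccc(/C=C2\SC(=O)N(Cc3ccc(C)cc3)C2=O)c1`: 1000 nM
Compound 2, `C=C(Br)C(=O)Nc1ccc(/C=C2\SC(=O)N(Cc3ccc(C)cc3)C2=O)cc1`: 6100 nM

Compound 1 carries the lower of the two numbers recorded in this assay. Compound 2, which differs in where the acrylamide-bearing ring is joined to the shared core, gives 6100 nM against 1000 nM for compound 1, a gap that lies beyond the scatter of the method. Within the data shown here, no single-site step between measured compounds exists here, so the series offers no direct precedent for the change now under consideration.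

Compound 3, `C=C(Br)C(=O)Nc1cccc(/C=C2\SC(=O)N(Cc3ccccc3)C2=O)c1`, is the next compound to be examined. Relative to compound 1 it differs as follows: hydrogen in place of methyl on an aromatic carbon. The acrylamide, the linkage and the core are unchanged.

Since nothing in the measured pair speaks to this particular methyl, the expectation for the step from compound 1 to compound 3, a 1.3-fold higher number from compound 1 to compound 3 (0.11 log units; within the scatter), is of a change that stays within the scatter rather than a clear shift in either direction. Compound 3 is accordingly estimated at 1300 nM, with a range from 500 nM to 3500 nM in this assay.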

Compound 3, half-maximal inhibitory concentration: 810 nM
For compound 3 the middle estimate is 1.6-fold (0.21 log units) above the measured one, and the stated range covers the measured number.
By their numbers in this assay, from the lowest: compounds 3 and 1 (each within the scatter of the next); then compound 2.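

In this assay, among these compounds, going from 4-methylbenzyl to benzyl gives a 1.2-fold lower number from compound 1 to compound 3 (0.09 log units; within the scatter), the first single-site step. It shows that the methyl on this aromatic carbon, para to a large group, can give way to hydrogen without a change that can be told from the scatter of the method, so in this pair the methyl is not required for the cytotoxicity read on these cells. No measurement at hand accounts for how little this change does.

From the compounds shown here alone, the two compounds in this step span only methyl and hydrogen at this carbon, so it remains open how this assay would read with a chlorine atom, a methoxy group, an amine or a carboxylic acid at the same place. Going by these compounds, it is equally open whether the benzyl group as a whole can be exchanged, for instance for a longer chain such as phenethyl, and whether removing the methyl would be just as silent on the framework of compound 2.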